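Chain extension on the shared core: cytotoxicity notes

The source may report more compounds than this note shows. Statements on the series, on what has been measured and on what is new or still open speak of the compounds shown alone.

Compound 2 `CCCCCCCCCCc1cc2cn(C3CCC(CO)O3)c(=O)nc2o1` is the reference point of this step. In a functional assay on HEL cells (Homo sapiens) (on this read-out higher numbers stand for lower toxicity in this test and lower numbers for higher toxicity in this test), compound 2 reaches only a limit, > 200000 nM, so no number is known for it. Compound 1 `CCCCCCCCc1cc2cn(C3CCC(CO)O3)c(=O)nc2o1` likewise gives, in this assay, a limit, > 112000 nM. Within the data shown here, the one measured step, a step that the two limits leave unreadable from compound 1 to compound 2, is thus of unreadable size, since the limit of > 112000 nM in this assay, at which 1 of the 2 values shown sits, and the limit of > 200000 nM in this assay, at which 1 of the 2 values shown sits, are both limits. Compound 3 `CCCCCCCCCCCCCCc1cc2cn(C3CCC(CO)O3)c(=O)nc2o1` differs from compound 2 by butyl in place of hydrogen on a saturated chain carbon, ten or more bonds along the chain from an aromatic carbon. No measured step can be read for this change, both known values being limits, and nothing in the series points to a change beyond the scatter. Among the measured compounds shown here, compound 3 is therefore expected to show no step of readable size, a number no higher from compound 2 to compound 3 (the limit leaves the size open). Compound 3 is estimated at 200000 nM, with a range from 60000 nM to 500000 nM, and the value is most likely to be reported again as a limit.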

Compound 3, half-maximal cytotoxic concentration: > 200000 nM
Compound 3 was reported as a limit; the forecaster's own chance of this, stated with the estimate: 80%; the middle value lies on the limit itself.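

In this assay, among these compounds, compound 3 gives > 200000 nM, which is a limit, so no step linking compound 1, compound 2 and compound 3 can be read. The compounds shown leave open the actual cytotoxic concentration of all three, and whether chain length changes it at all.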